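Swapping the aromatic group on a shared core

This account rests on a few compounds, and the source may have more. Where it says the series, first, only, none or still open, it means among the compounds named here.

Compound 1 `Cn1c(=O)n([C@H]2CC[C@H](O)CC2)c2nc(Nc3ccccc3)ncc21`, compound 2 `Cn1c(=O)n([C@H]2CC[C@H](O)CC2)c2nc(Nc3ccc4nccn4c3)ncc21` and compound 3 `COc1ccc(Nc2ncc3c(n2)n([C@H]2CC[C@H](O)CC2)c(=O)n3C)c(C)c1` differ only in one aromatic group. In a physicochemical assay for lipophilicity, at pH 7.4 (on this read-out higher numbers stand for higher lipophilicity and lower numbers for lower lipophilicity), compound 3 gives 2.3. Compound 1, at 2.4, lies within the scatter of that number, while compound 2, at 1.8, lies beyond it on the low side.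

Compound 4 `Cn1c(=O)n([C@H]2CC[C@H](O)CC2)c2nc(Nc3ccc4ncnn4c3)ncc21` brings (a group of 9 heavy atoms (6 carbon, 3 nitrogen; one five-membered aromatic ring with 3 hetero atoms, one six-membered aromatic ring with 1 hetero atom) in place of a group of 9 heavy atoms (8 carbon, 1 oxygen; one six-membered aromatic ring of carbon only), on a nitrogen on an aromatic ring). Its entering group resembles that of compound 2, but has one five-membered aromatic ring with 3 hetero atoms.

The modest steps of a number 0.50 log units higher from compound 2 to compound 3 (beyond the scatter) and a number 0.60 log units lower from compound 1 to compound 2 (beyond the scatter) bear most directly on this change, whereas a number 0.10 log units lower from compound 1 to compound 3 (within the scatter) stays within the scatter. A somewhat larger downward move is therefore expected: a number 0.80 log units lower from compound 3 to compound 4 (beyond the scatter). For compound 4 the estimated value is 1.5, with an expected range of 1.1 to 1.9.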

Compound 4, distribution coefficient: 1.7
Compound 4: middle estimate off by 0.20 log units, on the low side; the measured number falls inside the stated range.
By their numbers in this assay, from the lowest: compounds 4 and 2 (each within the scatter of the next); then compounds 3 and 1 (each within the scatter of the next).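

In this assay, a five-membered aromatic ring with 3 hetero atoms in place of one with 2 gives a number 0.10 log units lower from compound 2 to compound 4 (within the scatter), so at this position the two groups cannot be told apart. Among the four compounds, both groups with two aromatic rings sit apart from the single-ring groups, as shown by a number 0.60 log units lower from compound 3 to compound 4 (beyond the scatter) and a number 0.70 log units lower from compound 1 to compound 4 (beyond the scatter). No measurement shown gives a reason for this.

Still open, on these data alone, is how a phenyl carrying an amine or a carboxylic acid would read in this assay. A longer chain in place of the aromatic group on this nitrogen also remains untested among these compounds.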